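The source may report more compounds than this note shows. Statements on the series, on what has been measured and on what is new or still open speak of the compounds shown alone.

Measured compounds:
- compound 1, `C/C(=N\Nc1nc(-c2ccc(Br)cc2)cs1)c1cc2ccccc2o1`: 32700 nM
- compound 2, `C/C(=N\Nc1nc(-c2ccc(C)cc2)cs1)c1cc2ccccc2o1`: 14300 nM
- compound 3, `COc1ccc(-c2csc(N/N=C(\C)c3cc4ccccc4o3)n2)cc1`: 18700 nM

All three share one core and differ only in the group sitting on the outer benzene ring. In a functional assay on HeLa cells (Homo sapiens) for antiproliferative activity (a higher number here means a weaker inhibitor, a lower number a stronger inhibitor), compound 3 gives 18700 nM, which places it in the middle of the three numbers: one of the two steps that reach it is a 1.3-fold higher number from compound 2 to compound 3 (0.12 log units; within the scatter) and the other is a 1.7-fold lower number from compound 1 to compound 3 (0.24 log units; within the scatter), so all three compounds sit within the usual scatter of one another except for the pair linked by a 2.3-fold lower number from compound 1 to compound 2 (0.36 log units; beyond the scatter).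

Compound 4, `C/C(=N\Nc1nc(-c2ccccc2)cs1)c1cc2ccccc2o1`, has not yet been measured. Compared with compound 3 the change is hydrogen in place of methoxy on an aromatic carbon. Going by the values given here, the steps that bear on it are the two swaps at the same position that end in compound 3: a 1.7-fold lower number from compound 1 to compound 3 (0.24 log units; within the scatter) and a 1.3-fold higher number from compound 2 to compound 3 (0.12 log units; within the scatter), both within the scatter. Exchanging one small group for another at this spot has so far hardly moved this assay, so a similar outcome is expected for removing the group entirely, with no step beyond the scatter: a 1.1-fold higher number from compound 3 to compound 4 (0.03 log units; within the scatter). Compound 4 is therefore estimated at 20000 nM, with a range from 8000 nM to 50000 nM.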

Compound 4, half-maximal inhibitory concentration: 11700 nM
The estimate for compound 4 lay 1.7-fold (0.23 log units) above the measured number, within the range that was stated.
By their numbers in this assay, from the lowest: compounds 4, 2, 3 and 1 (each within the scatter of the next, the first and the last beyond it).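

With no group at all on this aromatic carbon, in this assay the change from 4-methoxyphenyl to phenyl stays within the scatter (a 1.6-fold lower number from compound 3 to compound 4 (0.20 log units; within the scatter)), and so does replacing methyl with hydrogen (a 1.2-fold lower number from compound 2 to compound 4 (0.09 log units; within the scatter)), so neither methoxy nor methyl is needed to hold the number at this level. Bromo is the only group here that separates clearly from hydrogen (a 2.8-fold lower number from compound 1 to compound 4 (0.45 log units; beyond the scatter)), although compound 1 stays within the scatter of compound 3, so the gap is modest and does not extend to every other compound. Nothing measured explains why bromo differs from hydrogen here.

As far as these compounds go, it remains open whether chloro or fluoro would track with bromo at this position. An amine or a carboxylic acid here might also move the number much further than any group shown.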